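The compounds below may be only part of what the source reports. "The series", "measured", "known", "first", "only" and "open" are said of these compounds alone.

Compound 1 `CCOC1=C(/C(C)=N/OCC(=O)Nc2cccc(F)c2)N(C)S(=O)(=O)c2ccccc21`: in a functional assay on THP-1 cells (Homo sapiens) for inhibition, read by ELISA, with stated times of 2 h and 48 h (on this read-out lower numbers stand for stronger inhibition and higher numbers for weaker inhibition), compound 1 gives > 20000 nM, which is a limit of the assay and not a number.
Compound 2 `CCOC1=C(/C(C)=N/OCC(=O)Nc2ccc(OC)cc2)N(C)S(=O)(=O)c2ccccc21`: in this assay compound 2 gives > 20000 nM, again a limit of the assay.
Compound 3 `C/C(=N\OCC(=O)Nc1cccc(F)c1)C1=C(O)c2ccccc2S(=O)(=O)N1C`: in this assay compound 3 gives > 20000 nM, also a limit of the assay.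

Within the data shown here, compound 3 therefore stands where every measured compound stands, at the limit of > 20000 nM in this assay, at which 3 of the 3 values shown sit; no compound gives a number that could order it against the others. The unmeasured compound 4 `COc1ccc(NC(=O)CO/N=C(\C)C2=C(O)c3ccccc3S(=O)(=O)N2C)cc1` differs from compound 3 in one place: 4-methoxyphenyl in place of 3-fluorophenyl on an amide-type nitrogen. The same exchange has been measured once before, on the core that carries ethyl on the oxygen, as a step that the two limits leave unreadable from compound 1 to compound 2, and the change that separates the two cores, a step that the two limits leave unreadable from compound 1 to compound 3, is equally unreadable. Both steps leave no size and no direction, so nothing in these three values supports an expectation of a step beyond the scatter, nor of a measurable number at all. The expected step is a number no higher from compound 3 to compound 4 (the limit leaves the size open), and compound 4 is therefore estimated at 20000 nM, most likely reported only as a limit, with a range from 8000 nM to 100000 nM.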

Compound 4, half-maximal inhibitory concentration: > 20000 nM
Compound 4 ended at the assay's limit; the forecaster's own chance of this, stated with the estimate: 85%; the middle value sits exactly at the limit.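

Compound 4 also gives a limit in this assay and not a number, so neither the step from compound 2 to compound 4 nor the step from compound 3 to compound 4 can be read: the limit of > 20000 nM in this assay, at which 4 of the 4 values shown sit. The compounds shown leave open whether either exchange changes inhibition at all.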